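The source may hold more compounds than are shown below. What is called first, only, known or untested is meant among the compounds shown, and "the series" means these compounds.

Compound 1 `CCCCOc1cc(C(C)(C)C)ccc1C/N=C(\S)NCc1ccc(NS(C)(=O)=O)c(F)c1` and compound 2 `CC(C)(C)COc1cc(C(C)(C)C)ccc1C/N=C(\S)NCc1ccc(NS(C)(=O)=O)c(F)c1` share one core and differ only in the chain on the oxygen; in a functional assay for inhibition of Vanilloid receptor (Rattus norvegicus) (a higher number here means a weaker inhibitor, a lower number a stronger inhibitor), compound 1 gives 20 nM, and compound 2 gives 66 nM. Compound 2 thus stands at the higher of the two numbers, the step of a 3.3-fold higher number from compound 1 to compound 2 (0.52 log units; beyond the scatter) lying beyond the scatter. Compound 3 `CC(C)(C)C(=O)OCc1cc(C(C)(C)C)ccc1C/N=C(\S)NCc1ccc(NS(C)(=O)=O)c(F)c1` has not yet been measured in this assay. It differs from compound 2 by (((tert-butyl)carbonyl)oxy)methyl in place of neopentyloxy on an aromatic carbon. Among the compounds with values here, the only measured step that bears on this position is the one from compound 1 to compound 2, which was modest, and the present change is a larger one, replacing the ether oxygen itself. An expected weakening of similar or somewhat greater size, carrying wide uncertainty, follows as a 1.8-fold higher number from compound 2 to compound 3 (0.26 log units; within the scatter). Compound 3 is therefore estimated at 120 nM, with a range from 30 nM to 500 nM.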

Compound 3, half-maximal inhibitory concentration: 15 nM
Compound 3: middle estimate off by 8.0-fold (0.90 log units), on the high side, and the stated range ends above it.
By their numbers in this assay, from the lowest: compounds 3 and 1 (each within the scatter of the next); then compound 2.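

In this assay, the step to the (((tert-butyl)carbonyl)oxy)methyl group is a 4.4-fold lower number from compound 2 to compound 3 (0.64 log units; beyond the scatter), so a tert-butyl end on this aromatic carbon does not by itself bring the weaker number seen with neopentyloxy. The measured step against butoxy is a 1.3-fold lower number from compound 1 to compound 3 (0.12 log units; within the scatter), which places this longer group, with its carbonyl and its second oxygen, level with the simple butoxy chain. The position therefore accepts a chain joined to the ring through a carbon rather than through an ether oxygen, at least in this one case. The data shown offer no explanation for the difference between the two tert-butyl-ended groups. Going by these compounds, it remains open whether the carbonyl or the tert-butyl end accounts for this result. An acetyloxymethyl group or a plain hydroxymethyl group at the same place would help separate the two.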